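The compounds below may be only part of what the source reports. "The series", "measured", "known", "first", "only" and "open" are said of these compounds alone.

Within the data shown here, compound 1 `CN(c1ncccc1CNc1nc(Nc2ccc3c(c2)CC(=O)N3)nc2[nH]cc(F)c12)S(C)(=O)=O` is the only member of this small set with a numerical result: in a functional assay on SMMC-7721 cells (Homo sapiens) for inhibition, read by MTT assay, with a stated time of 48 h (a higher number here means a weaker inhibitor, a lower number a stronger inhibitor), compound 1 gives 73200 nM. Compound 2 `CN(c1ncccc1CNc1nc(Nc2ccc(F)c(Cl)c2)nc2[nH]cc(F)c12)S(C)(=O)=O` carries a different group on a nitrogen on an aromatic ring, and in this assay compound 2 gives > 100000 nM, which is a limit of the assay rather than a number. The step of an at least 1.3-fold higher number from compound 1 to compound 2 (0.13 log units; that floor lies within the scatter) can therefore not be fully sized, because compound 2 sits at the limit of > 100000 nM in this assay, at which 1 of the 2 values shown sits. Compound 3 `COc1ccc(Nc2nc(NCc3cccnc3N(C)S(C)(=O)=O)c3c(F)c[nH]c3n2)cc1OC` is not yet measured. It differs from compound 2 by 3,4-dimethoxyphenyl in place of 3-chloro-4-fluorophenyl on a nitrogen on an aromatic ring. Among the measured compounds shown here, the one measured step bears only loosely on this change: it touched the same position but exchanged other groups, and it ends at a limit. No step beyond the scatter is therefore expected from compound 2 to compound 3, estimated as a number no higher from compound 2 to compound 3 (the limit leaves the size open). Compound 3 is expected to give about 100000 nM in this assay, within a range from 30000 nM to 300000 nM.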

Compound 3, half-maximal inhibitory concentration: 54800 nM
Compound 3: the middle estimate sits 1.8-fold (0.26 log units) above what was measured, within the range that was stated.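

With compound 3, the change to 3,4-dimethoxyphenyl on this nitrogen gives a measured number in this assay, with an at least 1.8-fold lower number from compound 2 to compound 3 (0.26 log units; that floor lies within the scatter); even this smallest possible step lies within the scatter, so no real gain can be claimed. Compound 2 gives only a limit, so the true size of that step cannot be read: the limit of > 100000 nM in this assay, at which 1 of the 3 values shown sits.

The groups of compound 1 and compound 3 can now be compared directly as numbers, and with a 1.3-fold lower number from compound 1 to compound 3 (0.13 log units; within the scatter) they cannot be told apart in this assay.

The compounds shown leave open whether a group of another kind on this nitrogen, such as a phenyl ring carrying an amine or a carboxylic acid, or a plain alkyl chain, would move the number beyond the scatter. They also leave open whether a single methoxy group would read like the pair in compound 3.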